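Swapping the Aryl Group on the Aromatic Core

A few compounds are considered here, and "the series" means these few. Any claim that something is new, unique, unknown or untested is made for them only; others in the source may bear on it.

Compound 1 `COc1ccc(-c2ccc3c(NCCCNCc4ccco4)ccnc3c2)cc1` and compound 2 `COc1ccc(-c2ccc3c(NCCCNCc4cc(F)ccc4OC)ccnc3c2)cc1` share a core that carries a saturated chain with amine nitrogens. In a physicochemical assay for acid dissociation, compound 1 gives 9.47, and compound 2 gives 9.47. Among the compounds with values here, the only measured step, no change at the digits printed from compound 1 to compound 2 (within the scatter), exchanged the group on a saturated chain carbon bound to an amine nitrogen and left the value where it was, so compound 2 stands level with compound 1. Compound 3 `COc1ccc(F)cc1CNCCCNc1ccnc2cc(CCc3ccccc3)ccc12` differs from compound 2 at a different place: phenethyl in place of 4-methoxyphenyl on an aromatic carbon. Within the data shown here, no measured step touches this aromatic carbon, so the single guide is that the one step did not shift the value beyond the scatter. The step to compound 3 is expected to be small, no change at the digits printed from compound 2 to compound 3 (within the scatter). Compound 3 is therefore estimated at 9.47, within 9.17 to 9.77.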

Compound 3, acid dissociation constant: 9.47
Beside the measured number, compound 3's estimate shows no gap at the digits printed; the range from low to high includes it.
By their numbers in this assay, from the lowest: compounds 1, 2 and 3 (each within the scatter of the next).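

In this assay, within the data shown here, phenethyl in place of 4-methoxyphenyl on this aromatic carbon of the shared core gives no change at the digits printed from compound 2 to compound 3 (within the scatter) and so adds the first measured step at this position. The earlier step exchanged only a group on the saturated chain, and now a second exchange at a different place also lies within the scatter, even though the entering group has no oxygen and no hydrogen-bond acceptor, unlike the group that leaves. Nothing measured here offers an explanation for this result, so it stands as an observation only.

On these data alone, whether other groups on this aromatic carbon would give the same value stays open, for example an amine, a carboxylic acid or a longer chain in place of phenethyl. Also open, as far as these compounds go, is what an amide in place of an amine nitrogen on the saturated chain would do to the value.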